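Ester for ketone on a shared dihydropyrimidinone-type series

The source may hold more compounds than are shown below. What is called first, only, known or untested is meant among the compounds shown, and "the series" means these compounds.

Compound 1 `CC1=C(C(=O)CC(C)C)C(c2ccoc2)NC(=O)N1` and compound 2 `CC1=C(C(=O)CC(C)C)C(c2ccsc2)NC(=O)N1` share one core and differ only in the five-membered aromatic ring. In an assay on membranes from HEK293 cells for displacement of a labelled ligand from adenosine receptor A2b (Homo sapiens), read by scintillation counting, with a stated time of 30 min (on this read-out lower numbers stand for stronger inhibition and higher numbers for weaker inhibition), compound 1 gives 1010 nM, and compound 2 gives 1000 nM. The step of a 1.0-fold lower number from compound 1 to compound 2 (0.00 log units; within the scatter) shows that the two rings are indistinguishable here. Compound 1 stands at the higher of the two numbers, but only within the scatter of compound 2.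

Compound 3 `CC1=C(C(=O)OC2CCC2)C(c2ccoc2)NC(=O)N1` keeps the furan-3-yl ring of compound 1 and changes the side chain: cyclobutyloxy in place of isobutyl on a carbonyl carbon. Within the data shown here, no measured step touches this position, so the only guidance is that the two known compounds sit close to each other. Compound 3 is therefore expected to stay near compound 1, with the step of a 1.0-fold lower number from compound 1 to compound 3 (0.00 log units; within the scatter) likely no larger than the scatter, in either direction. For compound 3 the estimate in this assay is 1000 nM, with a range from 250 nM to 4000 nM.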

Compound 3, inhibition constant: 307 nM
For compound 3 the middle estimate is 3.3-fold (0.51 log units) above the measured one; measured number inside the range.
By their numbers in this assay, from the lowest: compound 3; then compounds 2 and 1 (each within the scatter of the next).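

Unlike the swap of the five-membered aromatic ring, which stayed within the scatter, the side chain on the carbonyl carbon does move the number in this assay: a 3.3-fold lower number from compound 1 to compound 3 (0.52 log units; beyond the scatter). This modest step shows that this position responds to a change, and that cyclobutyloxy is favoured over isobutyl here, with the furan-3-yl ring held constant. The change brings in a four-membered ring, an oxygen and a hydrogen-bond acceptor all at once, and no measurement is available that explains the shift.

The compounds shown cannot separate the part played by the oxygen from that of the ring, which a cyclobutyl group placed directly on the carbonyl carbon or an isobutyloxy group could address. As far as these compounds go, it also remains open whether thiophen-3-yl would match furan-3-yl when paired with cyclobutyloxy.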